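Second methyl on compound 3: expected shift

This account rests on a few compounds, and the source may have more. Where it says the series, first, only, none or still open, it means among the compounds named here.

In a functional assay on SK-MEL-5 cells (Homo sapiens) for antiproliferative activity (a higher number here means a weaker inhibitor of growth, a lower number a stronger inhibitor of growth), compound 1 (`Oc1cc(-c2ccc3ccccc3c2)nc2ncccc12`) gives 3470 nM, compound 2 (`Cc1ccnc2nc(-c3ccc4ccccc4c3)cc(O)c12`) gives 437 nM and compound 3 (`Cc1ccc2c(O)cc(-c3ccc4ccccc4c3)nc2n1`) gives 3310 nM. Compound 3 therefore sits level with compound 1 within the scatter, while compound 2 has the lowest number of the three, beyond the scatter from both.

Compound 4 (`Cc1cc(C)c2c(O)cc(-c3ccc4ccccc4c3)nc2n1`) keeps the methyl of compound 3 and adds a methyl in place of hydrogen on an aromatic carbon, opposite the ring nitrogen and meta to a methyl group: methyl in place of hydrogen on an aromatic carbon.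

For the measured compounds named here, two measured steps bear on this. The methyl of compound 2 stands in the same place as the new methyl, and that change gave a 7.9-fold lower number from compound 1 to compound 2 (0.90 log units; beyond the scatter), a modest step beyond the scatter. The methyl already carried by compound 3 gave a 1.0-fold lower number from compound 1 to compound 3 (0.02 log units; within the scatter), within the scatter, so it offers no sign of altering the larger step. Going by the values given here, no measured compound carries both methyls, so additivity remains untested. A similar move to a lower number is expected, slightly smaller to allow for that uncertainty: a 6.6-fold lower number from compound 3 to compound 4 (0.82 log units; beyond the scatter). For compound 4 the estimated value is 500 nM, with an expected range of 150 nM to 1700 nM.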

Compound 4, concentration for 50% growth inhibition: 2190 nM
Estimate against measurement, compound 4: 4.4-fold (0.64 log units) below; measured number above the stated range.
By their numbers in this assay, from the lowest: compound 2; then compounds 4, 3 and 1 (each within the scatter of the next).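

The methyl opposite the ring nitrogen does not have a fixed effect in this assay: with the methyl of compound 3 already present, the step shrinks to a 1.5-fold lower number from compound 3 to compound 4 (0.18 log units; within the scatter) and stays within the scatter, so the result on the core of compound 1 does not carry over to this core: the same change on two cores in this assay, a 7.9-fold lower number (0.90 log units; beyond the scatter) from compound 1 to compound 2 and a 1.5-fold lower number (0.18 log units; within the scatter) from compound 3 to compound 4, 5.3-fold (0.72 log units) apart, beyond the scatter of two such steps. Read from the other side, the methyl of compound 3 is silent without the second methyl, yet with that methyl present it gives a 5.0-fold higher number from compound 2 to compound 4 (0.70 log units; beyond the scatter) and cancels most of the advantage of compound 2: the same change on two cores in this assay, a 1.0-fold lower number (0.02 log units; within the scatter) from compound 1 to compound 3 and a 5.0-fold higher number (0.70 log units; beyond the scatter) from compound 2 to compound 4, 5.3-fold (0.72 log units) apart, beyond the scatter of two such steps. Across these four compounds the two methyls are therefore not additive, and the low number of compound 2 depends on the other methyl being absent.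

The compounds shown do not explain this interaction, and they do not show whether it is specific to methyl. An ethyl or an amine opposite the ring nitrogen, with and without the methyl of compound 3, would test whether the loss follows any group at the second place or methyl alone.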